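Swapping a urea for a propanoyl on a pyrrolidine amide

The compounds below may be only part of what the source reports. "The series", "measured", "known", "first", "only" and "open" are said of these compounds alone.

Measured so far:
compound 1 `CCn1c(-c2cnc(C)nc2)nc2c(N[C@H]3CCN(C(=O)N4CC(OC)C4)C3)ncnc21` gives 10 10^-6 cm/s
compound 2 `CCn1c(-c2ccc(C(F)(F)F)nc2)nc2c(O[C@H]3CCN(C(=O)[C@H]4C[C@@H](OC)C4)C3)ncnc21` gives 35 10^-6 cm/s
compound 3 `CCC(=O)N1CC[C@H](Oc2ncnc3c2nc(-c2cnc(C)nc2)n3CC)C1` gives 21 10^-6 cm/s

These three compounds were measured in an ADME assay on LLC-PK1 cells (Sus scrofa) for permeability; a higher number here means that the compound crosses the layer faster, a lower number that the compound crosses the layer more slowly. Compound 1 stands lowest of the three. Compound 3 is its nearest neighbour, with a higher number, a gap beyond the scatter, and compound 2 is furthest, with a number beyond the scatter as well.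

The next compound, compound 4 `CCC(=O)N1CC[C@H](Nc2ncnc3c2nc(-c2cnc(C)nc2)n3CC)C1`, is not yet measured. It differs from compound 1 in one place: ethyl in place of 3-methoxyazetidin-1-yl on a carbonyl carbon. For the measured compounds named here, no pair of measured compounds shows this exact change, so no measured step can be quoted for it. What can be said is that compound 3, which carries the same propanoyl group on its ring nitrogen, gives 21 10^-6 cm/s, while compound 1 gives 10 10^-6 cm/s; compound 3 is otherwise not the same as compound 4, so this comparison is only a pointer.

On that basis the step in this assay from compound 1 to compound 4 is expected to be a 1.8-fold higher number from compound 1 to compound 4 (0.26 log units; within the scatter), upward, modest in size. Compound 4 is therefore estimated at 18 10^-6 cm/s, with a range from 9 10^-6 cm/s to 36 10^-6 cm/s.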

Compound 4, apparent permeability: 21 10^-6 cm/s
For compound 4 the middle estimate is 1.2-fold (0.07 log units) below the measured one; measured number inside the range.
By their numbers in this assay, from the lowest: compound 1; then compounds 3, 4 and 2 (each within the scatter of the next).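

For the compounds shown here, at this place on the carbonyl carbon, the first measured step in this assay comes from replacing 3-methoxyazetidin-1-yl with ethyl, giving a 2.1-fold higher number from compound 1 to compound 4 (0.32 log units; beyond the scatter) and lifting the number beyond the scatter. The change can therefore be read directly on a single pair, without leaning on compound 3, which also differs from compound 1 elsewhere. Nothing available explains why the number moves with this change.

The change removes the four-membered ring and its methoxy group together, so this pair cannot show which part matters; an unsubstituted azetidin-1-yl, or a methoxymethyl group on the same carbonyl carbon, would separate the two. As far as these compounds go, whether a methyl, a longer chain such as butyl, or a dimethylamino group at this place would give a similar number also remains open.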